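A few compounds are considered here, and "the series" means these few. Any claim that something is new, unique, unknown or untested is made for them only; others in the source may bear on it.

Measured compounds:
- Compound 1, `CONC(=S)N/N=C1\C(=O)N(CN2CCN(c3ccc(Cl)cc3)CC2)c2ccc(C)cc21`: 300000 nM
- Compound 2, `Cc1ccc2c(c1)/C(=N/NC(=S)NO)C(=O)N2CN1CCN(c2ccc(Cl)cc2)CC1`: 335000 nM
- Compound 3, `CN(C)CN1C(=O)/C(=N\NC(=S)NO)c2cc(Cl)ccc21`: 610000 nM

The three compounds were tested in an ADME assay on MT4 cells (Homo sapiens) for cytotoxicity, read by spectrophotometry, with a stated time of 5 days; on this read-out higher numbers stand for lower toxicity in this test and lower numbers for higher toxicity in this test. Compound 1 gives 300000 nM in this assay, compound 2 gives 335000 nM, and compound 3 gives 610000 nM. Compound 1 and compound 2 share a core and differ only in one place: methyl in place of hydrogen on an oxygen. This change made a step of a 1.1-fold lower number from compound 2 to compound 1 (0.05 log units; within the scatter).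

Compound 3 has the highest of the three numbers. Its nearest neighbour is compound 2, whose number lies within the scatter of it; compound 1 lies furthest off, beyond the scatter. The difference between the core of compound 3 and the core of compound 2 is not broken down here.

Compound 4, `CONC(=S)N/N=C1\C(=O)N(CN(C)C)c2ccc(Cl)cc21`, has not yet been measured in this assay. It differs from compound 3 in one place: methyl in place of hydrogen on an oxygen. This is the same change that was made from compound 2 to compound 1, with the same surroundings at the place. Because that earlier step was a 1.1-fold lower number from compound 2 to compound 1 (0.05 log units; within the scatter), the expected step from compound 3 to compound 4 is small as well, estimated at a 1.1-fold lower number from compound 3 to compound 4 (0.04 log units; within the scatter). On this basis compound 4 is expected to give about 560000 nM in this assay, with a likely range from 300000 nM to 1000000 nM. This expectation rests on a single earlier instance of the change, so it carries the uncertainty of that small sample.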

Compound 4, half-maximal cytotoxic concentration: 552000 nM
For compound 4 the middle estimate is 1.0-fold (0.01 log units) above the measured one; the range from low to high includes it.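

In this assay, the change from hydroxyamino to methoxyamino, with methyl in place of hydrogen on an oxygen whose other neighbour is an amide-type nitrogen, gave a 1.1-fold lower number from compound 3 to compound 4 (0.04 log units; within the scatter). Set beside the earlier instance of the same change on a different core, the new step agrees with it: the same change on two cores in this assay, a 1.1-fold lower number (0.05 log units; within the scatter) from compound 2 to compound 1 and a 1.1-fold lower number (0.04 log units; within the scatter) from compound 3 to compound 4, 1.0-fold (0.00 log units) apart, within the scatter of two such steps Within these two pairs, then, the change carries from one core to the other without a step beyond the scatter, but since neither step rises above the scatter, this shows only that the change left this read-out about where it was on these two cores, and it does not show that the same would hold on any other core in the series, or in any other test.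

The compounds shown have only hydrogen or methyl on this oxygen, so it remains open how this read-out would respond to a longer chain such as ethyl or to a benzyl group there. On these data alone, it also remains open what would follow if the hydroxyamino group gave way to a plain amine, with no oxygen at that place at all.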